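A few compounds are considered here, and "the series" means these few. Any claim that something is new, unique, unknown or untested is made for them only; others in the source may bear on it.

Three members of the series have so far been examined in an assay on isolated protein for inhibition of protein kinase C zeta type (Homo sapiens), with a stated time of 4 min, tested at 62.5 uM; a lower number here means less inhibition, a higher number more inhibition at the concentration tested (going by the name of the read-out). Compound 1 `CC(C)(C)C1=NN(c2cccc(Cl)c2)C(c2ccc(O)cc2)C1` gives 96.8% and stands highest of the three numbers, with compound 3 nearest and compound 2 furthest, both separated from it beyond the scatter. Compound 2 `CC(C)(C)C1=NN(c2ccccc2F)C(c2ccc(O)cc2)C1` gives 57.6%, and compound 3 `CC(C)(C)C1=NN(c2c(Cl)cccc2Cl)C(c2ccc(O)cc2)C1` gives 65.5%. Both steps away from the top number change the aryl group on an amine nitrogen in a ring: a number 39.2 percentage points lower from compound 1 to compound 2 (beyond the scatter), and a number 31.3 percentage points lower from compound 1 to compound 3 (beyond the scatter). The remaining step is a number 7.9 percentage points higher from compound 2 to compound 3 (within the scatter).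

Compound 4 `Oc1ccc(C2CC(c3ccccc3)=NN2c2cccc(Cl)c2)cc1` has not yet been measured. It departs from compound 1 at a different position of the shared core: phenyl in place of tert-butyl on a carbon with a double bond to nitrogen. Among the compounds with values here, none of the three measured steps touches the carbon with a double bond to nitrogen; all of them concern the group on the amine nitrogen in a ring, so no measured step bears directly on this change. Compound 1 in this assay already sits near the top of the scale, which leaves more room for a fall than a rise. The expected step is a number 11.8 percentage points lower from compound 1 to compound 4 (beyond the scatter), with no clear direction beyond the scatter. For compound 4 the estimate in this assay is 85%, within a range from 55% to 100%.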

Compound 4, a percentage reported as inhibition, at one concentration (the size of the read-out at that concentration, not a potency): 90.5%
Beside the measured number, compound 4's estimate is 5.5 percentage points below it; measured number inside the range.
By their numbers in this assay, from the lowest: compounds 2 and 3 (each within the scatter of the next); then compounds 4 and 1 (each within the scatter of the next).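

In this assay, phenyl in place of tert-butyl on the carbon with a double bond to nitrogen gives a number 6.3 percentage points lower from compound 1 to compound 4 (within the scatter) with the 3-chlorophenyl group held constant, so this first reading at the position separates the two groups by no more than the usual scatter. The entering phenyl brings 6 heavy atoms and an aromatic ring in place of the 4 heavy atoms of tert-butyl, yet this step stays small beside the two changes of the aryl group on the ring nitrogen, a number 39.2 percentage points lower from compound 1 to compound 2 (beyond the scatter) and a number 31.3 percentage points lower from compound 1 to compound 3 (beyond the scatter), which both lie beyond the scatter. Nothing shown accounts for the two groups reading alike here.

From the compounds shown here alone, how a methyl group, a cyclohexyl ring or a carboxylic acid would read on this carbon remains open, as does whether phenyl reads the same with 2-fluorophenyl or 2,6-dichlorophenyl on the ring nitrogen. Going by these compounds, with compound 1 and compound 4 both near the top of the scale at a single concentration, any difference in potency between them also remains open.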